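Methyl for phenyl on the piperazine nitrogen of a hydralazine hydrazide

This account rests on a few compounds, and the source may have more. Where it says the series, first, only, none or still open, it means among the compounds named here.

Measured compounds:
compound 1, `CCOC(=O)N1CCN(CC(=O)NNc2nncc3ccccc23)CC1`, > 1000000 nM in a functional assay on thoracic aorta (Rattus norvegicus, strain Wister); on this read-out lower numbers stand for stronger inhibition and higher numbers for weaker inhibition
compound 2, `O=C(CCN1CCN(c2ccccc2)CC1)NNc1nncc2ccccc12`, 270000 nM in this assay

The value of compound 1 in this assay is a limit of the assay and not a number. For the measured compounds named here, compound 2 therefore holds the only number given in this assay, its sole measured companion being a limit (the limit of > 1000000 nM in this assay, at which 1 of the 2 values shown sits). Compound 3, `CN1CCN(CCC(=O)NNc2nncc3ccccc23)CC1`, differs from compound 2 by methyl in place of phenyl on an amine nitrogen in a ring. Going by the values given here, no measured step covers such a change, so compound 3 is expected to remain close to compound 2, with a step of a 1.5-fold higher number from compound 2 to compound 3 (0.17 log units; within the scatter) that may not exceed the scatter. Compound 3 is estimated at 400000 nM, within 100000 nM to 2000000 nM.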

Compound 3, half-maximal inhibitory concentration: 360000 nM
Compound 3: the middle estimate sits 1.1-fold (0.05 log units) above what was measured, within the range that was stated.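

Methyl in place of phenyl on the amine nitrogen in the ring gives a 1.3-fold higher number from compound 2 to compound 3 (0.12 log units; within the scatter) in this assay. For the compounds shown here, this is the first step read at this position, and it shows that a single carbon can stand there in place of the whole aromatic ring with no change beyond the scatter. Compound 1 gives a limit of the assay and not a number, so it adds no second step: the limit of > 1000000 nM in this assay, at which 1 of the 3 values shown sits.

What the compounds shown leave open is whether a benzyl group, an acetyl group or a bare hydrogen on this nitrogen would read the same way. As far as these compounds go, a longer chain carrying a carboxylic acid at this position also remains open.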